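Swapping Pyridin-2-yl for 4-Cyanophenyl on Compound 3

The source may report more compounds than this note shows. Statements on the series, on what has been measured and on what is new or still open speak of the compounds shown alone.

Of the compounds shown here, three have so far been measured in a functional assay on Hep 3B2 cells (Homo sapiens) for inhibition, read by sulforhodamine B assay, with a stated time of 72 h; on this read-out lower numbers stand for stronger inhibition and higher numbers for weaker inhibition. Compound 1 `CC[C@H](Nc1ncnc2[nH]cnc12)c1nn(-c2cccnc2)c2cc(F)ccc12` reaches only a limit of the assay, giving > 40000 nM. Compound 3 `C[C@H](Nc1ncnc2[nH]cnc12)c1nn(-c2ccccn2)c2cc(F)ccc12` likewise reaches only a limit, giving > 40000 nM. Compound 2 `C[C@H](Nc1nc(N)nc(N)c1C#N)c1nn(-c2cccc(S(C)(=O)=O)c2)c2cc(F)ccc12`, built on a different core, gives 19700 nM in this assay. Compound 3 therefore stands together with compound 1 at the limit of > 40000 nM in this assay, at which 2 of the 3 values shown sit, without a numerical value of its own, and compound 2 is the only one of the three with a measured number.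

The next compound, compound 4 `C[C@H](Nc1ncnc2[nH]cnc12)c1nn(-c2ccc(C#N)cc2)c2cc(F)ccc12`, differs from compound 3 in one place: 4-cyanophenyl in place of pyridin-2-yl on an aromatic nitrogen. For the measured compounds named here, no step between two measured compounds is available to calibrate this change, and the limits on compound 1 and compound 3 leave the size of any step open. Compound 4 is expected to remain weak, with a step of an at least 1.3-fold lower number from compound 3 to compound 4 (0.12 log units; that floor lies within the scatter) that is not expected to carry it beyond the scatter of this assay. Compound 4 is thus estimated at 30000 nM, within a range from 8000 nM to 80000 nM, and a further limit rather than a number is the more likely outcome.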

Compound 4, half-maximal inhibitory concentration: 13500 nM
Compound 4: the middle estimate sits 2.2-fold (0.35 log units) above what was measured; the range from low to high includes it.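

In this assay, for the compounds shown here, 4-cyanophenyl in place of pyridin-2-yl on the aromatic nitrogen gives an at least 2.9-fold lower number from compound 3 to compound 4 (0.47 log units; beyond the scatter), the first step at this position that can be read, and it lies beyond the scatter. Compound 4 gives 13500 nM, a measured number, although that number is still high on this read-out. Only the lower bound of the step is fixed, and its true size stays open, because compound 3 has a limit of the assay rather than a number of its own: the limit of > 40000 nM in this assay, at which 2 of the 4 values shown sit.

From the compounds shown here alone, whether the step belongs to the nitrile or to the carbon-only aromatic ring remains open, and a plain phenyl group on the same nitrogen would separate the two. Also open, going by these compounds, is how an amine or a carboxylic acid in place of the nitrile would read, and whether the same change would give a step of similar size on the core of compound 2.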